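The compounds below may be only part of what the source reports. "The series", "measured", "known", "first", "only" and "open" are said of these compounds alone.

Compound 1 `COc1ccc(C2CC(c3ccc(NC(=O)c4cc(Cl)ccc4OC)cc3)=NN2C)cc1` gives in a functional assay on the whole organism (plasma, strain albino) for inhibition, with Rattus norvegicus as the target, with stated times of 1 h and 4 h, at a dose of 25 mg/kg by the oral route (on this read-out lower numbers stand for a weaker effect and higher numbers for a stronger effect at the one dose given), a reading of 69.6%, the lower of the two numbers measured. Among the compounds with values here, compound 2 `COc1ccc(Cl)cc1C(=O)Nc1ccc(C2=NN(C)C(c3ccccc3[N+](=O)[O-])C2)cc1` gives 83.8%, and the single measured step is a number 14.2 percentage points higher from compound 1 to compound 2 (beyond the scatter). Compound 3 `COc1ccc(C2CC(c3ccc(NC(=O)c4cc(Cl)ccc4OC)cc3)=NN2c2ccccc2)cc1` differs from compound 1 by phenyl in place of methyl on an amine nitrogen in a ring. Within the data shown here, no measured step touches the amine nitrogen in a ring; the step from compound 1 to compound 2 concerns a saturated ring carbon and so does not bear on this change. No step beyond the scatter is expected. Compound 3 is therefore estimated at 70%, range 45% to 90%, an expected step of a number 0.4 percentage points higher from compound 1 to compound 3 (within the scatter).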

Compound 3, a percentage reported as inhibition, in the whole organism at one dose (the size of the read-out at that dose, not a potency): 82.3%
The estimate for compound 3 lay 12.3 percentage points below the measured number; the range from low to high includes it.
By their numbers in this assay, from the lowest: compound 1; then compounds 3 and 2 (each within the scatter of the next).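

In this assay, phenyl in place of methyl on the amine nitrogen in a ring gives a number 12.7 percentage points higher from compound 1 to compound 3 (beyond the scatter), the first sign that this position, and not only the saturated ring carbon, moves the read-out. The entering group adds a six-membered aromatic ring of carbon only, with no hydrogen-bond donors or acceptors. No measurement at hand bears on the reason for this step.

From the compounds shown here alone, whether a benzyl group or a longer chain on this nitrogen would give a similar step remains open. Also open, going by these compounds, is how phenyl on this nitrogen and 2-nitrophenyl on the saturated ring carbon would act together in one compound.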